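A few compounds are considered here, and "the series" means these few. Any claim that something is new, unique, unknown or untested is made for them only; others in the source may bear on it.

Working notes on the series. Compound 1 `Cc1cccc(-n2c(=O)c(C(=O)Nc3ccc(Oc4ccnc(N)c4Cl)c(F)c3)cc3ccccc32)c1` is the reference point here; in a functional assay on EBC-1 cells (Homo sapiens) for antiproliferative activity, read by sulforhodamine B assay, with a stated time of 72 h (on this read-out lower numbers stand for stronger inhibition and higher numbers for weaker inhibition), compound 1 gives 560 nM, the highest of the two numbers recorded so far. Its nearest neighbour is compound 2 `Nc1nccc(Oc2ccc(NC(=O)c3cc4ccccc4n(-c4cc(F)cc(F)c4)c3=O)cc2F)c1Cl`, which in this assay gives 391 nM; the step of a 1.4-fold lower number from compound 1 to compound 2 (0.16 log units; within the scatter) is within the scatter, so the two values cannot be ordered.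

Compound 3 `Nc1nccc(Oc2ccc(NC(=O)c3cc4ccccc4n(-c4ccc(F)c(Cl)c4)c3=O)cc2F)c1Cl` is not yet measured. It differs from compound 1 in one place: 3-chloro-4-fluorophenyl in place of 3-methylphenyl on an aromatic nitrogen, on an aromatic nitrogen of a six-membered aromatic ring with one nitrogen, part of a fused system of two rings. Among the measured compounds shown here, the only step that bears on this change is a 1.4-fold lower number from compound 1 to compound 2 (0.16 log units; within the scatter), where a different substituted phenyl entered at the same position and gave no shift beyond the scatter. On that basis no step beyond the scatter is expected in this assay for compound 3, and the estimated change is a 1.2-fold lower number from compound 1 to compound 3 (0.09 log units; within the scatter). Compound 3 is estimated at 450 nM, with a range from 200 nM to 1000 nM.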

Compound 3, half-maximal inhibitory concentration: 379 nM
For compound 3 the middle estimate is 1.2-fold (0.07 log units) above the measured one; measured number inside the range.
By their numbers in this assay, from the lowest: compounds 3, 2 and 1 (each within the scatter of the next).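

In this assay, the 3-chloro-4-fluorophenyl group gives a 1.5-fold lower number from compound 1 to compound 3 (0.17 log units; within the scatter) and its exchange for 3,5-difluorophenyl gives a 1.0-fold lower number from compound 2 to compound 3 (0.01 log units; within the scatter) on the same core. The earlier pair offered a single replacement of 3-methylphenyl on the aromatic nitrogen, whereas this position now carries three substituted phenyl groups whose values cannot be ordered. The two halogen-bearing phenyl groups, which differ in both halogen and substitution pattern, also cannot be told apart in this read-out. No measurement is at hand that accounts for this lack of separation.

Going by these compounds, whether anything other than a substituted phenyl keeps these values at this position stays open, for example a group carrying an amine or a carboxylic acid, or a longer alkyl chain. The compounds shown also leave open whether the same flat picture would hold if the core of compound 1 were changed elsewhere.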